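Swapping the Outer Ring of a Sulfonamide Inhibitor

The source may hold more compounds than are shown below. What is called first, only, known or untested is meant among the compounds shown, and "the series" means these compounds.

Measured so far:
Compound 1, `COc1ccc(C(N)=O)cc1S(=O)(=O)Nc1cccnc1`: 1490 nM
Compound 2, `COc1ccc(Cl)cc1S(=O)(=O)Nc1cncc(-c2ccc(Cl)cc2)c1`: 198 nM
Compound 3, `COc1ccc(F)cc1S(=O)(=O)Nc1cncc(C(N)=O)c1`: 19 nM

All three were tested in an assay on isolated protein for inhibition of alkaline phosphatase, tissue-nonspecific isozyme (Homo sapiens); a lower number here means a stronger inhibitor, a higher number a weaker inhibitor. Compound 2 stands second highest of the three numbers. Its nearest neighbour is compound 1, whose number is higher, beyond the usual scatter; furthest away is compound 3, whose number is lower, again beyond the scatter. Compound 2 therefore sits in the middle of the known range.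

Compound 4, `COc1ccc(Cl)cc1S(=O)(=O)Nc1cncc(-c2cccc(C)c2)c1`, has not yet been measured in this assay. It differs from compound 2 in a single place: 3-methylphenyl in place of 4-chlorophenyl on an aromatic carbon. Among the measured compounds shown here, the leaving and entering groups are alike in size, and neither carries hydrogen-bond donors or acceptors; the only change is the identity of the substituent on the outer ring.

For the measured compounds named here, no measured pair shows this kind of swap, so there is no step to lean on. The expected step is a 1.5-fold higher number from compound 2 to compound 4 (0.18 log units; within the scatter), small, toward a somewhat higher number, and quite possibly within the scatter of repeated measurements. Compound 4 is therefore estimated at 300 nM, with a range from 100 nM to 900 nM.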

Compound 4, half-maximal inhibitory concentration: 160 nM
Estimate against measurement, compound 4: 1.9-fold (0.27 log units) above, within the range that was stated.
By their numbers in this assay, from the lowest: compound 3; then compounds 4 and 2 (each within the scatter of the next); then compound 1.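

In this assay, the outer ring at this position can go from 4-chlorophenyl to 3-methylphenyl with a 1.2-fold lower number from compound 2 to compound 4 (0.09 log units; within the scatter), so the two compounds cannot be told apart. Among the compounds shown here, this is the first single change that can be read, since the earlier compounds all differ from one another in more than one place; it shows that this particular swap, on an aromatic carbon two atoms from the ring nitrogen, leaves the number where it was, within what repeated measurements would give. Because the substituent and its place on the outer ring differ together in this pair, the step cannot say whether either one matters on its own, and nothing measured here bears on why the two compounds read alike.

The compounds shown leave open whether a plain phenyl ring with no substituent at all would read the same as these two. They also leave open whether the position would tolerate an outer ring carrying an amine or a carboxylic acid, groups quite unlike the chlorine and methyl compared here.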